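The source may report more compounds than this note shows. Statements on the series, on what has been measured and on what is new or still open speak of the compounds shown alone.

Compound 1 `Cn1cc(-c2ccccc2Oc2ccccc2)c2cc(C(=O)NCCCCCC(=O)NO)[nH]c2c1=O` is the reference point of this set. In an assay on isolated protein for inhibition of protein deacetylase HDAC6 (Homo sapiens), read by fluorescence (on this read-out lower numbers stand for stronger inhibition and higher numbers for weaker inhibition), compound 1 gives 3.4 nM, the lowest number among the three measured compounds. Its nearest neighbour is compound 3 `Cn1cc(-c2cc(C(C)(C)O)ccc2OC2CC2)c2cc(C(=O)NCc3ccc(C(=O)NO)cc3)[nH]c2c1=O`, which in this assay gives 7.9 nM; the furthest is compound 2 `Cn1cc(-c2ccccc2Oc2ccccc2)c2cc(C(=O)NCc3ccc(C(=O)NO)cc3)[nH]c2c1=O`, which gives 15.3 nM. Going by the values given here, the only single-point step between measured compounds is a 4.5-fold higher number from compound 1 to compound 2 (0.65 log units; beyond the scatter), where the chain carrying the hydroxycarbamoyl group is exchanged for a phenyl ring carrying the same group.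

Compound 4 `Cn1cc(-c2ccccc2Oc2ccccc2)c2cc(C(=O)NCCCCCCC(=O)Nc3ccccc3N)[nH]c2c1=O` keeps the core and the chain of compound 1 but carries ((2-aminophenyl)carbamoyl)methyl in place of hydroxycarbamoyl on a saturated chain carbon, five bonds along the chain from an amide-type nitrogen. Among the compounds with values here, no measured step touches the hydroxycarbamoyl group itself; the step from compound 1 to compound 2 only reshapes what sits between the amide nitrogen and that group, and it was modest. Within the data shown here, the change to compound 4 therefore has no direct precedent here, and any expectation is loosely held. Compound 4 is expected to give a higher number than compound 1, with a step of about a 290-fold higher number from compound 1 to compound 4 (2.47 log units; beyond the scatter). For compound 4 the estimate in this assay is 1000 nM, within a range from 100 nM to 10000 nM.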

Compound 4, half-maximal inhibitory concentration: > 500 nM
Compound 4: only a limit was reported (the forecaster's own chance of this, stated with the estimate: 15%); the middle value does not contradict the limit.
By their numbers in this assay, from the lowest: compound 1; then compounds 3 and 2 (each within the scatter of the next). At a limit, above all of these: compound 4.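

In this assay compound 4 gives > 500 nM, which is a limit of the assay and not a number. Going by these compounds alone, replacing hydroxycarbamoyl with ((2-aminophenyl)carbamoyl)methyl on this saturated chain carbon gives an at least 140-fold higher number from compound 1 to compound 4 (2.16 log units; beyond the scatter), a far larger change than the only earlier single-point step, a 4.5-fold higher number from compound 1 to compound 2 (0.65 log units; beyond the scatter), which left hydroxycarbamoyl in place. Among these compounds, the number in this assay therefore responds much more strongly to the group at the end of the chain than to the chain-to-phenyl exchange that leads to compound 2.

Going by these compounds, whether a carboxylic acid or a primary amide at this place would stay close to compound 1 remains open. On these data alone, it is also open whether a 2-aminophenyl amide on the phenyl linker of compound 2 would show the same large change.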